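A few compounds are considered here, and "the series" means these few. Any claim that something is new, unique, unknown or untested is made for them only; others in the source may bear on it.

The measured compounds and their values:

Compound 1, `COc1cc(C(=O)N/N=C/c2cccc(F)c2)cc(OC)c1OC`: 44.8%
Compound 2, `COc1ccc(C2OC(c3cc(OC)c(OC)c(OC)c3)=NN2C(C)=O)c(OC)c1`: -3.1%
Compound 3, `COc1cc(C2=NN(C(C)=O)C(c3cc(OC)c(OC)c(OC)c3)O2)cc(OC)c1OC`: -1.4%

All three were tested in a functional assay on BGC-823 cells (Homo sapiens) for antiproliferative activity, read by MTT assay, tested at 5 uM; a higher number here means a stronger effect of the compound at the concentration tested, a lower number a weaker effect. Compound 2 stands lowest of the three numbers. Its nearest neighbour is compound 3, whose value lies within the usual scatter of compound 2, so the two cannot be told apart. The furthest is compound 1, which lies beyond the scatter and so shows a clearly stronger effect than compound 2 in this assay.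

Compound 4, `COc1cc(C2=NN(C(C)=O)C(c3ccc(Cl)c([N+](=O)[O-])c3)O2)cc(OC)c1OC`, has not yet been measured. It differs from compound 2 in one place: 4-chloro-3-nitrophenyl in place of 2,4-dimethoxyphenyl on a saturated ring carbon. Within the data shown here, no step between two measured compounds that differ in just one place is available, so there is nothing in the measured set that shows what such an exchange does in this assay. Among the measured compounds shown here, the only guide is that compound 2 and compound 3, which share the same parts, both sit near zero inhibition. This step is expected to be small, likely upward but not far beyond the scatter, and our estimate for it is a number 11.1 percentage points higher from compound 2 to compound 4 (beyond the scatter). For compound 4 the expected value in this assay is 8%, with a range from -8% to 30%.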

Compound 4, a percentage reported as inhibition, at one concentration (the size of the read-out at that concentration, not a potency): 0%
Compound 4: middle estimate off by 8 percentage points, on the high side; measured number inside the range.
By their numbers in this assay, from the lowest: compounds 2, 3 and 4 (each within the scatter of the next); then compound 1.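

In this assay, among these compounds, putting 4-chloro-3-nitrophenyl in place of 2,4-dimethoxyphenyl on the saturated ring carbon gives a number 3.1 percentage points higher from compound 2 to compound 4 (within the scatter), the only step in the set that reads a single change at this position. This one exchange replaces both methoxy groups with a chlorine and a nitro group on the aromatic ring, yet it does not lift the read-out, and compound 4 gives 0% at the concentration tested. No measurement shown here accounts for this lack of separation between the two aryl groups.

A single exchange between two substituted phenyl groups leaves open whether anything placed on this carbon can raise the read-out, such as an unsubstituted phenyl, a pyridine ring, a carboxylic acid or an amine, and whether replacing the acetyl group with a longer acyl chain would do so. The much higher reading of compound 1, at 44.8%, also remains unconnected to this series, since compound 1 differs from compound 4 in more than one place.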